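Furan-3-yl to thiophen-3-yl: compound 3 to compound 4

The source may report more compounds than this note shows. Statements on the series, on what has been measured and on what is new or still open speak of the compounds shown alone.

Values so far in a functional assay on MCF7 cells (Homo sapiens) for antiproliferative activity, read by sulforhodamine B assay (a higher number here means a weaker inhibitor, a lower number a stronger inhibitor), are as follows
- compound 1 `O=C1NC(=O)c2ccc(I)cc2/C1=C/Nc1ccc(CN2CCCCC2)cc1` gives 1000 nM
- compound 2 `CN1CCN(c2ccc(N/C=C3\C(=O)NC(=O)c4ccc(-c5ccsc5)cc43)cc2)CC1` gives 2300 nM
- compound 3 `O=C1NC(=O)c2ccc(-c3ccoc3)cc2/C1=C/Nc1ccc(CN2CCCCC2)cc1` gives 1100 nM

Compound 3 lies within the scatter of compound 1 and beyond the scatter from compound 2, which has the higher number. The change to compound 4 `O=C1NC(=O)c2ccc(-c3ccsc3)cc2/C1=C/Nc1ccc(CN2CCCCC2)cc1` is thiophen-3-yl in place of furan-3-yl on an aromatic carbon with thiophen-3-yl in place of furan-3-yl on an aromatic carbon. For the measured compounds named here, the only measured step at this position is a 1.1-fold higher number from compound 1 to compound 3 (0.04 log units; within the scatter) and it stays small. Going by the values given here, compound 2 also carries thiophen-3-yl, but no measured step links it to compound 3. In this assay no shift beyond the scatter is expected, and the expected step is no change at the digits printed from compound 3 to compound 4 (within the scatter) in size. For compound 4 the estimated value is 1100 nM with an expected range from 600 nM to 2100 nM on repeat measurement.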

Compound 4, half-maximal inhibitory concentration: 3400 nM
For compound 4 the middle estimate is 3.1-fold (0.49 log units) below the measured one; measured number above the stated range.
By their numbers in this assay, from the lowest: compounds 1 and 3 (each within the scatter of the next); then compounds 2 and 4 (each within the scatter of the next).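

In this assay, this position does distinguish between groups: replacing the oxygen of furan-3-yl with sulfur gives a 3.1-fold higher number from compound 3 to compound 4 (0.49 log units; beyond the scatter), and thiophen-3-yl in place of iodo gives a 3.4-fold higher number from compound 1 to compound 4 (0.53 log units; beyond the scatter), unlike the step from iodo to furan-3-yl. With thiophen-3-yl held constant, (piperidin-1-yl)methyl in place of 4-methylpiperazin-1-yl gives a 1.5-fold higher number from compound 2 to compound 4 (0.17 log units; within the scatter). Nothing on hand accounts for the gap between the two rings.

From the compounds shown here alone, whether furan-3-yl behaves the same way alongside 4-methylpiperazin-1-yl remains open. So does the outcome at this position for a phenyl ring or a primary amine.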